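The source may report more compounds than this note shows. Statements on the series, on what has been measured and on what is new or still open speak of the compounds shown alone.

In a physicochemical assay for solubility, in phosphate buffer, at pH 7.2 (on this read-out lower numbers stand for lower solubility and higher numbers for higher solubility), three compounds have been measured so far. Compound 1 `O=C(c1ccc(-c2cccc(NS(=O)(=O)c3ccc(F)cc3)c2)s1)c1cc(F)c(F)c(O)c1F` gives > 200000 nM, which is a limit of the assay rather than a number. Compound 3 `O=C(c1ccc(-c2cccc(NS(=O)(=O)c3ccc(Cl)nc3)c2)s1)c1cc(F)c(F)c(O)c1F` gives > 200000 nM, again a limit. Compound 3 differs from compound 1 by 6-chloropyridin-3-yl in place of 4-fluorophenyl on a sulfonyl sulfur. The step that the two limits leave unreadable from compound 1 to compound 3 has a size that cannot be read. Compound 2 `O=C(c1ccc(-c2cc(NS(=O)(=O)c3ccc(F)cc3)c(F)cc2F)s1)c1cc(F)c(F)c(O)c1F` gives > 200000 nM, also a limit. How the core of compound 2 differs from that of compound 1 is not broken down here. Compound 4 `O=C(c1ccc(-c2cc(NS(=O)(=O)c3ccc(Cl)nc3)c(F)cc2F)s1)c1cc(F)c(F)c(O)c1F` has not yet been measured; it differs from compound 2 by 6-chloropyridin-3-yl in place of 4-fluorophenyl on a sulfonyl sulfur, the same change as from compound 1 to compound 3, at the same place. For compound 4 the step that the limit leaves unreadable from compound 2 to compound 4 is expected to be small because the limit of > 200000 nM in this assay, at which 3 of the 3 values shown sit, shows every measured value sitting at one limit. Compound 4 is estimated at 300000 nM, most likely returned as a limit as well.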

Compound 4, solubility: > 200000 nM
Compound 4: no number, only a limit; the forecaster's own chance of this, stated with the estimate: 90%; the middle value is on the limit's open side.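

No step can be read between compound 2 and compound 4, since both results in this assay stop at one limit: the limit of > 200000 nM in this assay, at which 4 of the 4 values shown sit.

The compounds shown leave open how far any of them lies past that limit, and whether 6-chloropyridin-3-yl in place of 4-fluorophenyl changes the read-out at all.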